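Ester variation on a shared core: compounds 1 to 3

A few compounds are considered here, and "the series" means these few. Any claim that something is new, unique, unknown or untested is made for them only; others in the source may bear on it.

compound 1 `C=C1C(=O)O[C@@H]2CC(C)=C([C@@H](C)CCCOC(C)=O)[C@@H](OC(=O)COc3ccc([N+](=O)[O-])cc3[N+](=O)[O-])[C@H]12`: > 100000 nM (a limit, not a number)
compound 2 `C=C1C(=O)O[C@@H]2CC(C)=C([C@@H](C)CCCOC(C)=O)[C@@H](OC(=O)COc3ccc4c(CC)noc4c3)[C@H]12`: 21200 nM
compound 3 `C=C1C(=O)O[C@@H]2CC(C)=C([C@@H](C)CCCOC(C)=O)[C@@H](OC(=O)COc3cccc4[nH]nnc34)[C@H]12`: not yet measured

Among the measured compounds shown here, compound 2 holds the only actual number in a functional assay on SGC-7901 cells (Homo sapiens) for cytotoxicity, read by sulforhodamine B assay, with a stated time of 72 h; on this read-out higher numbers stand for weaker inhibition and lower numbers for stronger inhibition; the other value shown is a limit. In this assay compound 1 sits at the limit > 100000 nM (the limit of > 100000 nM in this assay, at which 1 of the 2 values shown sits). Compound 2 gives 21200 nM. The step of an at least 4.7-fold lower number from compound 1 to compound 2 (0.67 log units; beyond the scatter) shows that the group on this oxygen can move the read-out beyond the scatter.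

Compound 3 differs from compound 2 by a group of 9 heavy atoms (6 carbon, 3 nitrogen; one five-membered aromatic ring with 3 hetero atoms, one six-membered aromatic ring of carbon only) in place of a group of 11 heavy atoms (9 carbon, 1 nitrogen, 1 oxygen; one five-membered aromatic ring with 2 hetero atoms, one six-membered aromatic ring of carbon only), on an oxygen on a saturated carbon. For the measured compounds named here, the single measured step at this position involves a different pair of groups, so it says only that exchanges here can matter, not in which direction this one will go. A step close to the scatter is expected, in either direction, with some chance of the limit. Compound 3 is estimated at 25000 nM with a range of 6000 nM to 100000 nM. The expected step is a 1.2-fold higher number from compound 2 to compound 3 (0.07 log units; within the scatter).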

Compound 3, half-maximal inhibitory concentration: 21100 nM
Compound 3: the middle estimate sits 1.2-fold (0.07 log units) above what was measured, and the stated range covers the measured number.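

In this assay, the exchange on this oxygen gives a 1.0-fold lower number from compound 2 to compound 3 (0.00 log units; within the scatter), so the two groups, one with a five-membered aromatic ring with 2 hetero atoms and no hydrogen-bond donor and one with 3 hetero atoms and 1 donor, are not told apart by this read-out. The second exchange gives an at least 4.7-fold lower number from compound 1 to compound 3 (0.67 log units; beyond the scatter), so two different groups, each with a five-membered aromatic ring and a six-membered aromatic ring of carbon only, now stand apart from the group of compound 1, which has only the six-membered ring. The size of that step remains a bound, as compound 1 gives a limit, not a number: the limit of > 100000 nM in this assay, at which 1 of the 3 values shown sits.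

Which part of these two groups carries the difference from compound 1 stays open. From the compounds shown here alone, it is also open how the read-out would respond to an amine, a carboxylic acid or a longer chain on this oxygen.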